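Sulfonyl-to-carbonyl swap at the aryl position of compound 1

This account rests on a few compounds, and the source may have more. Where it says the series, first, only, none or still open, it means among the compounds named here.

Compound 1 `CCOC(=O)[C@@H]1CCCN(S(=O)(=O)c2ccc(S(=O)(=O)N3CCCCC3)cc2)C1` is the reference point for this step. In a functional assay on BXPC-3 cells (Homo sapiens) for inhibition, read by MTT assay, with a stated time of 7 days (on this read-out higher numbers stand for weaker inhibition and lower numbers for stronger inhibition), compound 1 gives 3300 nM, the higher of the two numbers obtained so far. Compound 2 `CCOC(=O)[C@@H]1CCCN(S(=O)(=O)c2ccc(S(=O)(=O)N(CC)CC)cn2)C1` gives 1400 nM in this assay, a lower number than compound 1, and it differs from compound 1 in more than one place. Compound 3 `CCOC(=O)[C@@H]1CCCN(S(=O)(=O)c2ccc(S(=O)(=O)N(C)Cc3ccccc3)cc2)C1` is recorded only as a limit of this assay, > 30000 nM. Among the measured compounds shown here, the one step measured in a single place, an at least 9.0-fold higher number from compound 1 to compound 3 (0.95 log units; beyond the scatter), rests on that limit (the limit of > 30000 nM in this assay, at which 1 of the 3 values shown sits).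

Compound 4 `CCOC(=O)[C@@H]1CCCN(S(=O)(=O)c2ccc(C(=O)N(CC)CC)cc2)C1` is the next member to be tested. Relative to compound 1 the change is diethylcarbamoyl in place of (piperidin-1-yl)sulfonyl on an aromatic carbon. For the measured compounds named here, no measured step exchanges the sulfonyl for a carbonyl; the step from compound 1 to compound 3 touches only the amine on the sulfonyl, so it bears on the present change only loosely, and the comparison of compound 1 with compound 2 is confounded by the second difference. An estimated 1.8-fold higher number from compound 1 to compound 4 (0.26 log units; within the scatter), toward weaker inhibition, is therefore expected, placing compound 4 at an estimated 6000 nM with a range of 1500 nM to 25000 nM.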

Compound 4, half-maximal inhibitory concentration: 640 nM
Beside the measured number, compound 4's estimate is 9.4-fold (0.97 log units) above it; the whole stated range lies above it.
By their numbers in this assay, from the lowest: compound 4; then compound 2; then compound 1. At a limit, above all of these: compound 3.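

On an aromatic carbon para to a large group, the sulfonyl is not required for activity in this assay: diethylcarbamoyl in place of (piperidin-1-yl)sulfonyl gives a 5.2-fold lower number from compound 1 to compound 4 (0.71 log units; beyond the scatter). Among the compounds shown here, this is the only measured step that replaces the sulfonyl itself rather than only the amine on it, and it moves toward stronger inhibition. The step changes the carbonyl and the amine part together, and no measured property bears on it.

Still open, as far as these compounds go, is how much of the step belongs to the carbonyl and how much to the loss of the piperidine ring, which a piperidine amide on the core of compound 1 would separate. Also open, from the compounds shown here alone, is how a dimethylamide or a morpholine amide would read at this position.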